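Hydroxy for amino in a series at the limit

A few compounds are considered here, and "the series" means these few. Any claim that something is new, unique, unknown or untested is made for them only; others in the source may bear on it.

In a toxicity assay on MDCK cells (Canis lupus familiaris) for cytotoxicity, read by CCK-8 assay, with a stated time of 48 h (on this read-out lower numbers stand for higher toxicity in this test and higher numbers for lower toxicity in this test), compound 1 (`CCCOc1ccc(C(=O)NNc2c(Br)cccc2Br)cc1`) reads > 100000 nM which is a limit and not a number. Compound 2 (`CN(C)c1ccc(C(=O)NNc2c(Br)cccc2Br)cc1`) reads > 100000 nM which is also a limit. Compound 3 (`Nc1ccc(C(=O)NNc2c(Br)cccc2Br)cc1`) reads > 100000 nM so it too stands at a limit and has no exact number.

The change to compound 4 (`O=C(NNc1c(Br)cccc1Br)c1ccc(O)cc1`) is hydroxy in place of amino on an aromatic carbon and, in words, it puts hydroxy in place of amino on an aromatic carbon. All the measured compounds sit together: the limit of > 100000 nM in this assay, at which 3 of the 3 values shown sit, and nothing more exact is known. Two measured steps alter the group at that same place: a step that the two limits leave unreadable from compound 1 to compound 3 and a step that the two limits leave unreadable from compound 2 to compound 3 and neither gives a size to carry over, so no step beyond the usual scatter is expected in this assay in either direction. The estimated step is a number no higher from compound 3 to compound 4 (the limit leaves the size open) and no direction is favoured. For compound 4 the expected value is 100000 nM with an estimated range from 50000 nM to 200000 nM and the assay may again report only a limit.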

Compound 4, half-maximal cytotoxic concentration: > 100000 nM
Compound 4: no number, only a limit (the forecaster's own chance of this, stated with the estimate: 80%); the middle value lies on the limit itself.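

Compound 4 also reads > 100000 nM, a limit and not a number, so no step can be read between it and compound 1, compound 2 or compound 3: the limit of > 100000 nM in this assay, at which 4 of the 4 values shown sit.

The compounds shown leave open how far any of them lies from that limit, and whether changing this group alters the read-out at all.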